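Lengthening the piperazine linker: from ethyl to butyl

The source may report more compounds than this note shows. Statements on the series, on what has been measured and on what is new or still open speak of the compounds shown alone.

Measured in a functional assay on CCRF-CEM cells for antagonist activity at C-X-C chemokine receptor type 4 (Homo sapiens), read by calcium flux, with stated times of 25 min and 90 s; on this read-out lower numbers stand for stronger inhibition and higher numbers for weaker inhibition:
compound 1 `c1ccc2c(c1)CN[C@@H](CN(CCCN1CCNCC1)[C@H]1CCCc3cccnc31)C2`: 17 nM
compound 2 `c1ccc2c(c1)CN[C@@H](CN(CCN1CCNCC1)[C@H]1CCCc3cccnc31)C2`: 553 nM

Compound 2 stands at the weaker end of these two numbers; its closest neighbour, compound 1, carries the (piperazin-1-yl)methyl group in place of the piperazin-1-yl group of compound 2, on the chain carbon two bonds from the amine nitrogen. For the measured compounds named here, that single change is the only step measured here, and it was large: a 33-fold higher number from compound 1 to compound 2 (1.51 log units; beyond the scatter).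

Compound 3 `c1ccc2c(c1)CN[C@@H](CN(CCCCN1CCNCC1)[C@H]1CCCc3cccnc31)C2` takes the same chain in the opposite direction and further: 2-(piperazin-1-yl)ethyl in place of piperazin-1-yl on a saturated chain carbon, two bonds along the chain from an amine nitrogen. Read one bond further out, this is the 2-(piperazin-1-yl)ethyl of compound 2 becoming 4-(piperazin-1-yl)butyl, so compound 3 is longer than both measured compounds. Because a 33-fold higher number from compound 1 to compound 2 (1.51 log units; beyond the scatter) shows that shortening the chain cost a great deal in this assay, lengthening it again is expected to recover much of that loss; whether going past the length of compound 1 holds or gives back some of the gain is not shown by any measured pair. Compound 3 is therefore expected to show a 14-fold lower number from compound 2 to compound 3 (1.14 log units; beyond the scatter), landing at an estimated 40 nM, with a range from 10 nM to 200 nM.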

Compound 3, half-maximal inhibitory concentration: 66 nM
For compound 3 the middle estimate is 1.7-fold (0.22 log units) below the measured one, within the range that was stated.
By their numbers in this assay, from the lowest: compound 1; then compound 3; then compound 2.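

The chain length at this position does not act in one direction. Going from 2-(piperazin-1-yl)ethyl to 4-(piperazin-1-yl)butyl gives an 8.4-fold lower number from compound 2 to compound 3 (0.92 log units; beyond the scatter) in this assay, so a longer chain recovers much of what the shortest one lost. The recovery is only partial, and going from 3-(piperazin-1-yl)propyl to 4-(piperazin-1-yl)butyl gives a 3.9-fold higher number from compound 1 to compound 3 (0.59 log units; beyond the scatter), which leaves the 3-(piperazin-1-yl)propyl chain of compound 1 as the strongest of the three, with inhibition falling away on both sides of that length. No measurement at hand explains why this chain length is favoured.

With only three lengths shown, it remains open whether a still longer chain, such as 5-(piperazin-1-yl)pentyl, would weaken inhibition further or level off. From the compounds shown here alone, it is also open how much depends on the piperazine ring itself, and a piperidine or a simple primary amine at the end of the 3-(piperazin-1-yl)propyl chain's length would address that question.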